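The source may report more compounds than this note shows. Statements on the series, on what has been measured and on what is new or still open speak of the compounds shown alone.

Of the compounds shown here, three have so far been tested in an ADME assay on HEK-293T cells (Homo sapiens) for cytotoxicity, read by MTT assay, with a stated time of 24 h; a lower number here means that less compound is tolerated, a higher number that more compound is tolerated. Compound 1 `Cc1ccccc1C(=O)n1c(-c2cn(-c3ccccc3)nc2-c2ccc(F)cc2)nc2ccccc21` gives 189000 nM, compound 2 `O=C(c1ccc(Cl)cc1)n1c(-c2cn(-c3ccccc3)nc2-c2ccc(C(F)(F)F)cc2)nc2ccccc21` gives 181000 nM, and compound 3 `Cc1ccc(-c2nn(-c3ccccc3)cc2-c2nc3ccccc3n2C(=O)c2ccc(Cl)cc2)cc1` gives 216000 nM. Compound 2 holds the lowest of the three numbers, yet its gaps to compound 1 and to compound 3 both lie within the scatter, so the three behave alike. Compound 4 `Cc1cncc(C(=O)n2c(-c3cn(-c4ccccc4)nc3-c3ccc(C(F)(F)F)cc3)nc3ccccc32)c1` differs from compound 2 in one place: 5-methylpyridin-3-yl in place of 4-chlorophenyl on a carbonyl carbon. For the measured compounds named here, the only measured single change, a 1.2-fold higher number from compound 2 to compound 3 (0.08 log units; within the scatter), concerns a group on an aromatic carbon rather than on the carbonyl carbon, so it bears on the new change only loosely. No shift beyond the scatter is therefore expected, a 1.0-fold higher number from compound 2 to compound 4 (0.02 log units; within the scatter). Compound 4 is estimated at 190000 nM, between 110000 nM and 320000 nM.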

Compound 4, half-maximal cytotoxic concentration: 123000 nM
For compound 4 the middle estimate is 1.5-fold (0.19 log units) above the measured one, within the range that was stated.
By their numbers in this assay, from the lowest: compounds 4, 2, 1 and 3 (each within the scatter of the next).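

For the compounds shown here, the only measured change on this carbonyl carbon, 5-methylpyridin-3-yl in place of 4-chlorophenyl, gives in this assay a 1.5-fold lower number from compound 2 to compound 4 (0.17 log units; within the scatter). A ring holding a nitrogen and a hydrogen-bond acceptor can therefore stand here with no shift beyond the scatter, something the earlier step on an aromatic carbon could not show. Nothing measured here speaks to a cause for this step. The compounds shown do not separate the ring nitrogen from the methyl. On these data alone, whether an amine or a carboxylic acid on this carbonyl carbon would also stay within the scatter remains open.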